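This account rests on a few compounds, and the source may have more. Where it says the series, first, only, none or still open, it means among the compounds named here.

Measured so far in an ADME assay on Vero cells (Chlorocebus sabaeus) for cytotoxicity, read by neutral red uptake, tested at 3150 ug/mL; a higher number here means a weaker effect of the compound at the concentration tested, a lower number a stronger effect:
compound 1 `Cc1ccc(C2SCC(=O)N2CCN2CCCCC2)cc1`: 12%
compound 2 `O=C1CSC(c2ccccc2Cl)N1CCN1CCCCC1`: 22%

On the numbers shown, compound 2 and compound 1 stand together: a number 10 percentage points higher from compound 1 to compound 2 (within the scatter). Both numbers sit low in this assay.

Compound 3 `O=C1CSC(c2ccc(Cl)cc2)N1CCN1CCCCC1` is not yet measured. Its change from compound 2: 4-chlorophenyl in place of 2-chlorophenyl on a saturated ring carbon. For the measured compounds named here, the only measured step that bears on it is a number 10 percentage points higher from compound 1 to compound 2 (within the scatter), which put 2-chlorophenyl in place of 4-methylphenyl on the same saturated ring carbon and stayed within the scatter. No measured step exchanges 2-chlorophenyl for 4-chlorophenyl, so nothing shown supports a step beyond the scatter in either direction for this change. For compound 3 the expected step in this assay is therefore a number 2 percentage points lower from compound 2 to compound 3 (within the scatter). The estimate for compound 3 in this assay is 20%, with a range from 5% to 40%.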

Compound 3, a percentage reported as activity, at one concentration (the size of the read-out at that concentration, not a potency): 11%
Compound 3: the middle estimate sits 9 percentage points above what was measured, within the range that was stated.
By their numbers in this assay, from the lowest: compounds 3, 1 and 2 (each within the scatter of the next, the first and the last beyond it).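

In this assay the saturated ring carbon proves sensitive to where the chlorine sits on its phenyl group: 4-chlorophenyl in place of 2-chlorophenyl, with identical atom counts, gives a modest change (a number 11 percentage points lower from compound 2 to compound 3 (beyond the scatter)). Chloro in place of methyl on an aromatic carbon gives no change that can be separated from the scatter (a number 1 percentage points lower from compound 1 to compound 3 (within the scatter)), so 4-chlorophenyl and 4-methylphenyl cannot be told apart here. Nothing available accounts for the difference between the two chlorophenyl isomers.

Only two chlorine placements are shown, so 3-chlorophenyl and 2-methylphenyl would show whether this difference follows the placement of the substituent or belongs to chlorine alone. The piperidine end is also constant throughout, leaving open how a morpholine there would read in this assay.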